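Swapping the ring on the sulfonyl sulfur: morpholine to piperidine

This account rests on a few compounds, and the source may have more. Where it says the series, first, only, none or still open, it means among the compounds named here.

Compound 1 `CC(O)(C(=O)Nc1ccc(S(=O)(=O)N2CCCC2)cc1)C(F)(F)F`: 880 nM
Compound 2 `CC(O)(C(=O)Nc1ccc(S(N)(=O)=O)cc1)C(F)(F)F`: 12800 nM
Compound 3 `CC(O)(C(=O)Nc1ccc(S(=O)(=O)N2CCOCC2)cc1)C(F)(F)F`: 5850 nM

In an assay on a protein complex (Cavia porcellus) with sulfonylurea receptors; K-ATP channels (Homo sapiens) as the target (on this read-out higher numbers stand for weaker inhibition and lower numbers for stronger inhibition), compound 3 stands second highest of the three numbers: a 6.6-fold higher number from compound 1 to compound 3 (0.82 log units; beyond the scatter), while a 2.2-fold lower number from compound 2 to compound 3 (0.34 log units; beyond the scatter). Compound 4 `CC(O)(C(=O)Nc1ccc(S(=O)(=O)N2CCCCC2)cc1)C(F)(F)F` differs from compound 3 by piperidin-1-yl in place of morpholin-4-yl on a sulfonyl sulfur. The measured steps that bear on this are the ring changes on the same sulfonyl sulfur: a 15-fold higher number from compound 1 to compound 2 (1.16 log units; beyond the scatter) and a 6.6-fold higher number from compound 1 to compound 3 (0.82 log units; beyond the scatter), both showing that the ring carrying only carbon and nitrogen gives the lowest number among these compounds. Compound 4 is therefore expected to give a lower number than compound 3, a step estimated as a 3.9-fold lower number from compound 3 to compound 4 (0.59 log units; beyond the scatter). The value estimated for compound 4 is 1500 nM, with a range from 500 nM to 5000 nM.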

Compound 4, half-maximal inhibitory concentration: 9250 nM
Compound 4: the middle estimate sits 6.2-fold (0.79 log units) below what was measured, outside the stated range (above it).
By their numbers in this assay, from the lowest: compound 1; then compounds 3, 4 and 2 (each within the scatter of the next, the first and the last beyond it).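

At this position on the sulfonyl sulfur, swapping morpholin-4-yl for piperidin-1-yl barely registers, with a 1.6-fold higher number from compound 3 to compound 4 (0.20 log units; within the scatter), so the ring oxygen of compound 3 makes no difference beyond the scatter. Piperidin-1-yl also matches the plain amino group, with a 1.4-fold lower number from compound 2 to compound 4 (0.14 log units; within the scatter), while pyrrolidin-1-yl stands apart, with an 11-fold higher number from compound 1 to compound 4 (1.02 log units; beyond the scatter), so among these compounds the low number belongs to that one ring, not to rings on the sulfur in general. Nothing shown here offers a reason for this. Still open, from the compounds shown here alone, is whether azetidin-1-yl or azepan-1-yl would side with compound 1 or with compound 4. Also open, going by these compounds, is whether a methyl group on the pyrrolidine ring would keep the low number of compound 1.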